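A few compounds are considered here, and "the series" means these few. Any claim that something is new, unique, unknown or untested is made for them only; others in the source may bear on it.

Measured compounds:
compound 1, `CCC(CC)Cn1c(Cc2cc(OC)c(OC)c(OC)c2)nc2c(N)ncnc21`, 158000 nM
compound 2, `CCCn1c(Cc2cc(OC)c(OC)c(OC)c2)nc2c(N)nc(F)nc21`, 25100 nM
compound 3, `C=CCCn1c(Cc2cc(OC)c(OC)c(OC)c2)nc2c(N)nc(F)nc21`, 33100 nM

In a functional assay on MCF7 cells (Homo sapiens) for antiproliferative activity (a higher number here means a weaker inhibitor, a lower number a stronger inhibitor), compound 1 stands at the highest of the three numbers; compound 3 sits nearest, and compound 2 furthest, both beyond the scatter from compound 1. Compounds 2 and 3 carry a fluorine on the shared core that compound 1 lacks, and their chains on the aromatic nitrogen differ as well, so their distance from compound 1 cannot be laid at any single change.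

Compound 4, `COc1cc(Cc2nc3c(N)ncnc3n2CCOC(C)C)cc(OC)c1OC`, has not been measured in this assay. It differs from compound 1 by isopropoxymethyl in place of pentan-3-yl on a saturated chain carbon bound to an aromatic nitrogen. Going by the values given here, the only step measured within a chain on the aromatic nitrogen is a 1.3-fold higher number from compound 2 to compound 3 (0.12 log units; within the scatter), a change that stayed within the scatter. That step touches a different part of the chain and introduces no oxygen, so it bears on the present change only loosely. Among the compounds with values here, with one chain step inside the scatter as the sole guide, a step within or only slightly beyond the scatter is expected, with no firm direction, as a 1.3-fold lower number from compound 1 to compound 4 (0.12 log units; within the scatter). Compound 4 is therefore estimated at 120000 nM, with a range from 40000 nM to 400000 nM.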

Compound 4, half-maximal inhibitory concentration: 38900 nM
For compound 4 the middle estimate is 3.1-fold (0.49 log units) above the measured one, and the stated range ends above it.
By their numbers in this assay, from the lowest: compounds 2, 3 and 4 (each within the scatter of the next); then compound 1.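

In this assay, going by these compounds alone, the exchange of pentan-3-yl for isopropoxymethyl gives a 4.1-fold lower number from compound 1 to compound 4 (0.61 log units; beyond the scatter) and so shows that a change at this place, on a saturated chain carbon bound to an aromatic nitrogen, can move the number beyond the scatter, while the only earlier chain step, a 1.3-fold higher number from compound 2 to compound 3 (0.12 log units; within the scatter) and at another part of the chain, stayed within it. The two groups have the same heavy-atom count and neither carries a ring, but the entering group has an oxygen and a hydrogen-bond acceptor where the leaving group has neither. No measurement at hand offers an explanation for this step.

The compounds shown leave open whether the oxygen itself or the altered shape of the chain goes with the lower number, and how a chain ending in a hydroxyl group or an amine would compare at this place. They also leave open whether the same exchange would give a similar step on the fluorine-bearing core of compound 2 and compound 3.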